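Carbamate aryl swap on a shared core: notes toward compound 4

A few compounds are considered here, and "the series" means these few. Any claim that something is new, unique, unknown or untested is made for them only; others in the source may bear on it.

Measured so far in a functional assay on PANC-1 cells (Homo sapiens) for inhibition, read by MTT assay, with a stated time of 24 h, tested at 10 uM; a higher number here means more inhibition at the concentration tested (going by the name of the read-out), a lower number less inhibition:
compound 1 `COc1ccccc1NC(=O)Oc1cc(=O)n(CCCO)c2c1CC(CC=C(C)C)C(C)(C)C2` — 0%
compound 2 `COc1ccc(NC(=O)Oc2cc(=O)n(CCCO)c3c2CC(C/C=C(\C)CCC=C(C)C)C(C)(C)C3)cc1` — 0%
compound 3 `COc1ccccc1NC(=O)Oc1cc(=O)n(CCCO)c2c1CC(C/C=C(\C)CCC=C(C)C)C(C)(C)C2` — 0%

Compound 3 stands level with compounds 1 and 2 at the digits shown. The step of no change at the digits printed from compound 1 to compound 3 (within the scatter) and the step of no change at the digits printed from compound 2 to compound 3 (within the scatter) both lie within the scatter, so neither the chain extension nor the move of the methoxy group on the aryl ring of the carbamate has shifted the read-out.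

Compound 4 `CC(C)=CCC/C(C)=C/CC1Cc2c(OC(=O)Nc3ccc(Cl)c(Cl)c3)cc(=O)n(CCCO)c2CC1(C)C` is the next member. Its difference from compound 3 is 3,4-dichlorophenyl in place of 2-methoxyphenyl on an amide-type nitrogen. Within the data shown here, no measured pair carries exactly this change. Among the measured compounds shown here, the only step that touches the same aryl group is no change at the digits printed from compound 2 to compound 3 (within the scatter), and it was flat; the step of no change at the digits printed from compound 1 to compound 3 (within the scatter), elsewhere on the core, was flat as well. For the measured compounds named here, on that basis the expectation for this assay is no step beyond the scatter, a number 3 percentage points higher from compound 3 to compound 4 (within the scatter), with the whole series so far sitting at the floor of the read-out.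

Compound 4 is therefore estimated at 3%, within a range of 0% to 15%.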

Compound 4, a percentage reported as inhibition, at one concentration (the size of the read-out at that concentration, not a potency): 0%
The estimate for compound 4 lay 3 percentage points above the measured number; measured number inside the range.
By their numbers in this assay, from the lowest: compounds 1, 2, 3 and 4 (each within the scatter of the next).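

In this assay, the aryl group on the amide-type nitrogen has now been changed in kind, not only in where its methoxy group sits: 3,4-dichlorophenyl in place of 2-methoxyphenyl gives no change at the digits printed from compound 3 to compound 4 (within the scatter), and 3,4-dichlorophenyl in place of 4-methoxyphenyl gives no change at the digits printed from compound 2 to compound 4 (within the scatter). Neither methoxyphenyl group is therefore set apart from a dichlorophenyl group at this position, although with the whole series at the floor of the read-out, these aryl groups cannot be ranked. No supporting data bear on this result.

Still open, on these data alone, is whether any group on the amide-type nitrogen lifts the read-out off the floor, for example cyclohexyl or a phenyl ring carrying a carboxylic acid or an amine.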